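The source may hold more compounds than are shown below. What is called first, only, known or untested is meant among the compounds shown, and "the series" means these compounds.

Compound 2 `CCCCSCC1C2CCC(O2)C1C/C=C\CCCC(=O)O` gives 1000 nM in a functional assay on a cell-free system (plasma) for inhibition of thromboxane A2 receptor (Homo sapiens) (a higher number here means a weaker inhibitor, a lower number a stronger inhibitor), the lower of the two numbers in hand; compound 1 `CCSCC1C2CCC(O2)C1C/C=C\CCCC(=O)O` gives 5400 nM. Among the measured compounds shown here, the single measured step, a 5.4-fold lower number from compound 1 to compound 2 (0.73 log units; beyond the scatter), enlarged this same chain. Compound 3 `CCC/C=C\CSCC1C2CCC(O2)C1C/C=C\CCCC(=O)O` enlarges it once more: pent-1-en-1-yl in place of propyl on a saturated chain carbon bound to a sulfur. For the measured compounds named here, only that one step bears on the change, and it was modest, so a further lowering of similar or smaller size is expected in this assay, not none. Compound 3 is therefore estimated at 400 nM, with a range from 100 nM to 1500 nM, an expected step of a 2.5-fold lower number from compound 2 to compound 3 (0.40 log units; beyond the scatter).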

Compound 3, half-maximal inhibitory concentration: 5700 nM
The estimate for compound 3 lay 14-fold (1.15 log units) below the measured number; measured number outside the range, above it.
By their numbers in this assay, from the lowest: compound 2; then compounds 1 and 3 (each within the scatter of the next).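

In this assay, enlarging the group on a saturated chain carbon bound to a sulfur does not keep lowering the number: pent-1-en-1-yl in place of propyl gives a 5.7-fold higher number from compound 2 to compound 3 (0.76 log units; beyond the scatter). Pent-1-en-1-yl in place of methyl gives a 1.1-fold higher number from compound 1 to compound 3 (0.02 log units; within the scatter), so the advantage of the propyl compound is gone and the response to size at this position is not steady. Nothing measured here accounts for this reversal. Going by these compounds, whether a saturated pentyl chain at this place would match compound 2 or compound 3 stays open, so the added length and the double bond cannot be told apart.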